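From 3-carbamoylphenyl to 2,6-difluorophenyl on the amide

The source may hold more compounds than are shown below. What is called first, only, known or untested is meant among the compounds shown, and "the series" means these compounds.

For the measured compounds named here, in an ADME assay on LLC-MK2 cells (Macaca mulatta) for cytotoxicity, read by spectrophotometry and crystal violet staining, with a stated time of 4 days (a higher number here means that more compound is tolerated, a lower number that less compound is tolerated), compound 2 (`CC(C)n1ncc2c(C(=O)Nc3cccc(C(N)=O)c3)cc(-c3cccs3)nc21`) gives 25000 nM and holds the only actual number so far. In this assay compound 1 (`CC(C)n1ncc2c(C(=O)Nc3ccc(F)cc3)cc(-c3cccs3)nc21`) gives > 200000 nM as a limit of the assay and not a number. Compound 3 (`CC(C)n1ncc2c(C(=O)Nc3c(F)cccc3F)cc(-c3cccs3)nc21`) carries 2,6-difluorophenyl in place of 3-carbamoylphenyl on an amide-type nitrogen. Going by the values given here, one measured step bears on this change, an at least 8.0-fold lower number from compound 1 to compound 2 (0.90 log units; beyond the scatter) ending in that limit-bounded comparison (the limit of > 200000 nM in this assay, at which 1 of the 2 values shown sits) and also involving 3-carbamoylphenyl. A move back toward a higher number is therefore expected, with a 4.0-fold higher number from compound 2 to compound 3 (0.60 log units; beyond the scatter) as the estimated step in this assay here. The estimate for compound 3 is 100000 nM with an expected range of 30000 nM to 200000 nM in this case.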

Compound 3, half-maximal cytotoxic concentration: > 200000 nM
Compound 3: no number, only a limit (the forecaster's own chance of this, stated with the estimate: 50%); at least 2.0-fold (0.30 log units) between middle value and limit.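

Placing 2,6-difluorophenyl on the amide-type nitrogen in place of 3-carbamoylphenyl gives, in this assay, an at least 8.0-fold higher number from compound 2 to compound 3 (0.90 log units; beyond the scatter), so a second replacement at this position now reverses the lower number of compound 2. For the compounds shown here, compound 3, like compound 1, gives a limit of the assay and not a number, leaving 3-carbamoylphenyl as the only group here with a measured number: the limit of > 200000 nM in this assay, at which 2 of the 3 values shown sit. The step from compound 1 to compound 3 cannot be read, since both values are limits. Going by these compounds, whether a carboxylic acid or an amine in place of the carbamoyl group would also give a lower number remains open.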